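Furan for fluorophenyl on a histamine H2 agonist

The source may report more compounds than this note shows. Statements on the series, on what has been measured and on what is new or still open speak of the compounds shown alone.

Measured compounds: compound 1 `Cc1nc(N)sc1CCCN/C(N)=N/C(=O)NC(C)c1cccc(F)c1`, 0.85; compound 2 `Cc1nc(N)sc1CCCN/C(N)=N/C(=S)N[C@H](C)c1ccccc1`, 0.87; compound 3 `CCC(NC(=O)/N=C(\N)NCCCc1sc(N)nc1C)c1ccccc1`, 0.93.

In a functional assay on Right cardiac atrium for agonist activity at histamine H2 receptor (Cavia porcellus), with a stated time of 30 min, in the presence of a further agent that is not named here (on this read-out higher numbers stand for larger maximal responses and lower numbers for smaller maximal responses), compound 1 gives 0.85. Its number sits at the low side of the three, yet the gaps to compound 2 and compound 3 both lie within the usual scatter of repeated measurements, so the three compounds cannot be ranked on this read-out. Compound 4 `Cc1nc(N)sc1CCCN/C(N)=N/C(=O)NC(C)c1ccco1` has not been measured. It differs from compound 1 in one place: furan-2-yl in place of 3-fluorophenyl on a saturated chain carbon bound to an amide-type nitrogen and a saturated chain carbon. Among the compounds with values here, since no pair of measured compounds differs in one place, no measured step guides the comparison. The step a number 0.020 higher from compound 1 to compound 4 (within the scatter) is expected to be none beyond the scatter. Compound 4 is therefore estimated at 0.87, with a range from 0.72 to 1.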

Compound 4, intrinsic activity: the largest response reached, as a fraction of the reference agonist's: 1
Compound 4: middle estimate off by 0.13, on the low side; the measured number falls inside the stated range.
By their numbers in this assay, from the lowest: compounds 1, 2, 3 and 4 (each within the scatter of the next, the first and the last beyond it).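

In this assay, furan-2-yl in place of 3-fluorophenyl on a saturated chain carbon bound to an amide-type nitrogen and a saturated chain carbon gives a number 0.15 higher from compound 1 to compound 4 (beyond the scatter). Within the data shown here, this is the first single change that can be read at this position, and it shows that a five-membered aromatic ring with 1 hetero atom can stand there without loss of maximal response. Nothing at hand bears on the cause of this rise.

As far as these compounds go, whether the rise depends on the ring oxygen stays open, and a thiophen-2-yl group at this carbon would test it. Also open, from the compounds shown here alone, is whether an unsubstituted phenyl group on the same scaffold would give a similar number.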